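Removing a para-fluoro: a small step in a mouse assay

The compounds below may be only part of what the source reports. "The series", "measured", "known", "first", "only" and "open" are said of these compounds alone.

Compound 1 `O=C1CCC2(c3ccc(F)cc3)OCCCN12` was tested in a functional assay on the whole organism (Central nervous system) with Mus musculus as the target (a higher number here means that more compound is needed for the effect, a lower number that less compound is needed), where compound 1 gives 100 mg/kg. Within the data shown here, the only other measured compound, compound 2 `Cc1ccc(C23CCC(=O)N2CCCO3)c(C)c1`, gives 150 mg/kg in this assay, a gap that lies within the usual scatter, so the two numbers cannot be told apart. Compound 3 `O=C1CCC2(c3ccccc3)OCCCN12` has not yet been measured; it differs from compound 1 by hydrogen in place of fluoro on an aromatic carbon. Among the measured compounds shown here, no measured pair shows this change, so a step of about a 1.1-fold higher number from compound 1 to compound 3 (0.04 log units; within the scatter) is expected, none beyond the scatter. Compound 3 is expected to give about 110 mg/kg, between 55 mg/kg and 220 mg/kg.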

Compound 3, dose for half-maximal effect: 150 mg/kg
The estimate for compound 3 lay 1.4-fold (0.13 log units) below the measured number; measured number inside the range.
By their numbers in this assay, from the lowest: compounds 1, 2 and 3 (each within the scatter of the next).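

Hydrogen in place of fluoro on the aromatic carbon, para to a large group, gives a 1.5-fold higher number from compound 1 to compound 3 (0.18 log units; within the scatter) in this assay, the first measured step at this position. The fluoro can therefore be removed without the number leaving the usual scatter of this mouse assay. Nothing measured here bears on what lies behind this result.

On these data alone, whether a larger group at this position, such as trifluoromethyl, methoxy or an amine, would move the number beyond the scatter stays open. The compounds shown also leave open whether any change elsewhere on the shared core would do so.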